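Compound 4: a larger group in place of methyl

The source may hold more compounds than are shown below. What is called first, only, known or untested is meant among the compounds shown, and "the series" means these compounds.

Compound 1 `CCC(C)(C)/N=C(\NC#N)Nc1ccc(I)cc1`: 1.4 nM
Compound 2 `CC(C)(C)/N=C(\NC#N)Nc1ccc(C#N)cc1`: 530 nM
Compound 3 `C/N=C(\NC#N)Nc1ccc(C#N)cc1`: 130000 nM

In a functional assay (aorta) for inhibition, with Rattus norvegicus as the target (on this read-out lower numbers stand for stronger inhibition and higher numbers for weaker inhibition), compound 3 gives the highest number of the three, 130000 nM. Compound 4 `CCC(C)(C)/N=C(\NC#N)Nc1ccc(C#N)cc1` differs from it in one place: 1,1-dimethylpropyl in place of methyl on a double-bonded nitrogen. Within the data shown here, the one measured step at that place is a 250-fold higher number from compound 2 to compound 3 (2.39 log units; beyond the scatter), and read in reverse it favours the larger group. Compound 1 already carries 1,1-dimethylpropyl and gives 1.4 nM, whereas compound 2 gives 530 nM, but those two also differ elsewhere. A large step towards a lower number is therefore expected, slightly exceeding the measured one. The expected change is a 650-fold lower number from compound 3 to compound 4 (2.81 log units; beyond the scatter). For compound 4 the estimate is 200 nM, with an expected range from 50 nM to 800 nM.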

Compound 4, half-maximal inhibitory concentration: 130 nM
Beside the measured number, compound 4's estimate is 1.5-fold (0.19 log units) above it; low and high end bracket the measured number.
By their numbers in this assay, from the lowest: compound 1; then compound 4; then compound 2; then compound 3.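

In this assay, the gain at the double-bonded nitrogen does not stop at tert-butyl: 1,1-dimethylpropyl in place of methyl gives a 1000-fold lower number from compound 3 to compound 4 (3.00 log units; beyond the scatter), and the single added methyl alone still gives a 4.1-fold lower number from compound 2 to compound 4 (0.61 log units; beyond the scatter). With 1,1-dimethylpropyl held fixed, cyano in place of iodo on an aromatic carbon gives a 93-fold higher number from compound 1 to compound 4 (1.97 log units; beyond the scatter), so that change can now be read on its own. Nothing given here explains these steps. Going by these compounds, whether the number keeps falling with a longer chain or a cyclohexyl group on that nitrogen remains open, as does how chloro or methoxy would compare with iodo and cyano on the aromatic carbon.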